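Methylsulfanyl for trifluoroethoxy on the aryl piperazine

The compounds below may be only part of what the source reports. "The series", "measured", "known", "first", "only" and "open" are said of these compounds alone.

Three members of the series have numbers in a functional assay for antagonist activity at Alpha-1A adrenergic receptor (Oryctolagus cuniculus); on this read-out lower numbers stand for tighter binding and higher numbers for weaker binding. Compound 1 `COc1ccccc1N1CCN(CCCNc2ncccc2C(=O)N(C)C)CC1` gives 1.59 nM. Compound 2 `COc1ccccc1N1CCN(CCCNc2ncccc2C(=O)C2CC2)CC1` gives 0.501 nM, and the step of a 3.2-fold lower number from compound 1 to compound 2 (0.50 log units; beyond the scatter) came from cyclopropyl in place of dimethylamino on a carbonyl carbon. Compound 3 `CN(C)C(=O)c1cccnc1NCCCN1CCN(c2ccccc2OCC(F)(F)F)CC1` gives 0.1 nM, the lowest of the three; the step of a 16-fold lower number from compound 1 to compound 3 (1.20 log units; beyond the scatter) came from trifluoromethyl in place of hydrogen on a saturated chain carbon bound to an oxygen on an aromatic ring.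

Compound 4 `CSc1ccccc1N1CCN(CCCNc2ncccc2C(=O)N(C)C)CC1` is the next candidate for this assay. Against compound 3 the change is methylsulfanyl in place of 2,2,2-trifluoroethoxy on an aromatic carbon; counted out, (methylsulfanyl in place of 2,2,2-trifluoroethoxy on an aromatic carbon). For the measured compounds named here, the one measured step that bears on this position is the one from compound 1 to compound 3, where building the trifluoroethoxy out of methoxy gave the large gain just quoted. Compound 4 undoes that and puts a small group back in place, one that differs from the methoxy of compound 1 only in the atom attached to the ring. The expected direction is therefore a higher number, with the estimated step of a 12-fold higher number from compound 3 to compound 4 (1.08 log units; beyond the scatter) placing compound 4 close to compound 1. For compound 4 the expected value in this assay is 1.2 nM, within 0.3 nM to 5 nM.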

Compound 4, dissociation constant: 0.631 nM
For compound 4 the middle estimate is 1.9-fold (0.28 log units) above the measured one; measured number inside the range.
By their numbers in this assay, from the lowest: compound 3; then compounds 2 and 4 (each within the scatter of the next); then compound 1.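

In this assay, the same aromatic carbon on the shared core now has three groups to compare, and the atom attached to the ring matters: methylsulfanyl in place of methoxy gives a gain of its own (a 2.5-fold lower number from compound 1 to compound 4 (0.40 log units; beyond the scatter)), so the number at this position does not depend only on building out the chain. Set against the 2,2,2-trifluoroethoxy group, methylsulfanyl still loses ground (a 6.3-fold higher number from compound 3 to compound 4 (0.80 log units; beyond the scatter)), which places compound 4 between compound 3 and compound 1, with each of these steps beyond the scatter, and shows that part of the gain seen with 2,2,2-trifluoroethoxy can be reached by a group with 2 heavy atoms rather than 6. Nothing in hand gives a reason for this order of the three groups.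

The compounds shown leave open whether the sulfur gain and the fluorine gain would add up in a single group such as 2,2,2-trifluoroethylsulfanyl, and whether ethoxy or ethylsulfanyl would separate the effect of chain length from that of the trifluoromethyl. Going by these compounds, it also remains open whether the cyclopropyl ketone of compound 2 would carry over onto a methylsulfanyl compound.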